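The source may hold more compounds than are shown below. What is called first, only, known or untested is meant among the compounds shown, and "the series" means these compounds.

Measured so far: compound 1 `N=C(N)c1ccc(-c2ccc(-c3cc(Cl)cc(Cl)c3)s2)s1` and compound 2 `COc1ccc(-c2ccc(-c3ccc(C(=N)N)o3)o2)cc1`. In a functional assay on M14 cells (Homo sapiens) for inhibition, read by sulforhodamine B assay, with a stated time of 48 h (on this read-out lower numbers stand for stronger inhibition of growth and higher numbers for weaker inhibition of growth), compound 1 gives 2020 nM; in this assay compound 2 gives 1470 nM. Compound 2 has the lower of the two numbers, but its gap to compound 1 lies within the scatter, so no order can be read from the pair. The next compound is compound 3 `N=C(N)c1ccc(-c2ccc(-c3ccc(Cl)cc3)o2)o1`, which differs from compound 2 only in chloro in place of methoxy on an aromatic carbon. Without a measured step to lean on, only a small change is expected for compound 3, a 1.2-fold lower number from compound 2 to compound 3 (0.09 log units; within the scatter), not clearly beyond the scatter in either direction. Compound 3 is therefore expected near 1200 nM, in a range of 500 nM to 3000 nM.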

Compound 3, concentration for 50% growth inhibition: 1850 nM
The estimate for compound 3 lay 1.5-fold (0.19 log units) below the measured number; the measured number falls inside the stated range.
By their numbers in this assay, from the lowest: compounds 2, 3 and 1 (each within the scatter of the next).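

In this assay, within the data shown here, chloro in place of methoxy on an aromatic carbon, para to a large group, gives a 1.3-fold higher number from compound 2 to compound 3 (0.10 log units; within the scatter) and is the first single-place step. This position therefore does not separate methoxy, which carries a hydrogen-bond acceptor, from chloro, which carries none. No available evidence bears on the reason for this result. From the compounds shown here alone, what an amine, a carboxylic acid or a longer chain would give at this position remains open. So does whether any group here moves the number beyond the scatter.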